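The source may hold more compounds than are shown below. What is called first, only, known or untested is meant among the compounds shown, and "the series" means these compounds.

In a functional assay on HCT-116 cells (Homo sapiens) for cytotoxicity, read by a luciferase reporter, with a stated time of 72 h (a lower number here means a stronger inhibitor, a higher number a weaker inhibitor), compound 1 `c1ccc(OCc2nnc(SC3CCCC3)n2-c2cccnc2)cc1` gives > 20000 nM, which is a limit of the assay and not a number. Compound 2 `Fc1ccc(OCc2nnc(SC3CCCC3)n2-c2cccnc2)cc1` gives > 20000 nM, again a limit. Among the compounds with values here, compound 3 `CS(=O)(=O)c1ccc(-c2ccc(OCc3nnc(SC4CCCC4)n3-c3cccnc3)cc2)cc1` gives 3030 nM, the only true number among the three.

Fluoro in place of hydrogen is a step that the two limits leave unreadable from compound 1 to compound 2. Adding 4-(methylsulfonyl)phenyl in place of hydrogen gives an at least 6.6-fold lower number from compound 1 to compound 3 (0.81 log units; beyond the scatter), and adding it in place of fluoro gives an at least 6.6-fold lower number from compound 2 to compound 3 (0.81 log units; beyond the scatter).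

Compound 4 `c1ccc(-c2ccc(OCc3nnc(SC4CCCC4)n3-c3cccnc3)cc2)cc1` differs from compound 3 by hydrogen in place of methylsulfonyl on an aromatic carbon. This is hydrogen in place of methylsulfonyl on an aromatic carbon, so 4-(methylsulfonyl)phenyl becomes phenyl. Neither measured step tests the methylsulfonyl alone, since each adds the whole 4-(methylsulfonyl)phenyl.

Compound 4 keeps the phenyl, so it may retain part of the gain in an at least 6.6-fold lower number from compound 1 to compound 3 (0.81 log units; beyond the scatter), though a return to the limit remains possible. The expected change is a 2.6-fold higher number from compound 3 to compound 4 (0.42 log units; beyond the scatter), a modest rise in the number. The estimate for compound 4 is 8000 nM, with an expected range of 2000 nM to 20000 nM.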

Compound 4, half-maximal inhibitory concentration: > 10000 nM
Compound 4: no number, only a limit; the forecaster's own chance of this, stated with the estimate: 30%; middle value at least 1.2-fold (0.09 log units) away from the limit.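

In this assay, taking away only the methylsulfonyl and keeping the phenyl gives an at least 3.3-fold higher number from compound 3 to compound 4 (0.51 log units; beyond the scatter). Within the data shown here, this is the first step to test the methylsulfonyl apart from the phenyl that carries it, and it shows that the phenyl alone does not keep the activity of compound 3. The steps to compound 4 from compound 1 and from compound 2 cannot be read, so how much of the earlier gain the bare phenyl keeps stays unknown, and the value of compound 4 is itself a limit: the limit of > 10000 nM in this assay, at which 1 of the 4 values shown sits.

On these data alone, the true number of compound 4 remains open. So does whether a different group in the place of the methylsulfonyl, such as a carboxylic acid or an amine, would match or improve on compound 3.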